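Phenoxy in place of thiophene on a pyrrolidine amide

The compounds below may be only part of what the source reports. "The series", "measured", "known", "first", "only" and "open" are said of these compounds alone.

In an assay on HEK293 cells for inhibition of N-acylethanolamine-hydrolyzing acid amidase (Rattus norvegicus), read by LC-MS, with a stated time of 30 min (on this read-out lower numbers stand for stronger inhibition and higher numbers for weaker inhibition), compound 1 `O=C(CCc1ccc(-c2cccc(F)c2)cc1)N1CCCC1` gives 1800 nM, and compound 2 `O=C(CCc1ccc(-c2ccsc2)cc1)N1CCCC1` gives 2500 nM. The only step shown, a 1.4-fold higher number from compound 1 to compound 2 (0.14 log units; within the scatter), stays within the scatter, so compound 2 and compound 1 cannot be told apart on this read-out. Compound 3 `O=C(CCc1ccc(Oc2ccccc2)cc1)N1CCCC1` differs from compound 2 by phenoxy in place of thiophen-3-yl on an aromatic carbon. Within the data shown here, no measured step swaps a ring for a phenoxy group, so the one ring swap seen, which changed little, is the only guide. For compound 3 the estimated step is a 1.3-fold lower number from compound 2 to compound 3 (0.10 log units; within the scatter), none beyond the scatter. Compound 3 is therefore expected near 2000 nM, plausibly between 600 nM and 6500 nM.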

Compound 3, half-maximal inhibitory concentration: > 100000 nM
Compound 3 gave a limit, no number; the forecaster's own chance of this, stated with the estimate: 10%; at least 50-fold (1.69 log units) between middle value and limit.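

In this assay compound 3 gives > 100000 nM, which is a limit of the assay and not a number. Among these compounds, the two rings joined directly to the core, in compound 1 and compound 2, could not be told apart, so the earlier compounds gave no sign that this position was sensitive to change. Phenoxy, whose ring is joined through an oxygen, shows that it is: the result is an at least 40-fold higher number from compound 2 to compound 3 (1.60 log units; beyond the scatter) and an at least 55-fold higher number from compound 1 to compound 3 (1.74 log units; beyond the scatter). As far as these compounds go, it remains open whether the oxygen link itself matters, or whether a benzyl group, with a carbon link, or an anilino group, with an amine link, would give a similar result.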